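This account rests on a few compounds, and the source may have more. Where it says the series, first, only, none or still open, it means among the compounds named here.

In an assay on isolated protein for inhibition of DNA topoisomerase 1 (Homo sapiens), with a stated time of 30 min, tested at 100 uM (a lower number here means less inhibition, a higher number more inhibition at the concentration tested (going by the name of the read-out)), compound 2 `Oc1ccc(-c2cc(-c3ccccc3O)cc(-c3ccccc3O)n2)cc1` gives 0.3%, the highest of the three numbers shown, though its lead over each neighbour lies within the usual scatter. Compound 1 `Oc1ccccc1-c1cc(-c2ccccc2O)nc(-c2ccccc2O)c1` gives 0% and compound 3 `Oc1cccc(-c2cc(-c3ccccc3O)cc(-c3ccccc3O)n2)c1` gives 0% in this assay. The three steps among them are small: a number 0.3 percentage points higher from compound 1 to compound 2 (within the scatter), no change at the digits printed from compound 1 to compound 3 (within the scatter) and a number 0.3 percentage points lower from compound 2 to compound 3 (within the scatter). Compound 4 `Oc1ccc(-c2cc(-c3ccc(O)cc3)nc(-c3ccccc3O)c2)cc1` differs from compound 2 in one place: 4-hydroxyphenyl in place of 2-hydroxyphenyl on an aromatic carbon. The step that bears on this change most directly is a number 0.3 percentage points higher from compound 1 to compound 2 (within the scatter), the same exchange of hydroxyphenyl groups, and it stayed within the scatter. No step beyond the scatter is therefore expected in this assay; the estimated step is a number 0.2 percentage points higher from compound 2 to compound 4 (within the scatter). Compound 4 is estimated at 0.5%, expected to fall between 0% and 8%.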

Compound 4, a percentage reported as inhibition, at one concentration (the size of the read-out at that concentration, not a potency): 0%
Compound 4: middle estimate off by 0.5 percentage points, on the high side, within the range that was stated.
By their numbers in this assay, from the lowest: compounds 1, 3, 4 and 2 (each within the scatter of the next).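

In this assay, the exchange of 2-hydroxyphenyl for 4-hydroxyphenyl opposite the ring nitrogen gives a number 0.3 percentage points lower from compound 2 to compound 4 (within the scatter). The exchange therefore leaves the read-out within the scatter even when the core already carries a 4-hydroxyphenyl group. No information on hand offers a reason for this flat result.

These compounds do not show whether any group at this position can raise inhibition beyond the scatter. From the compounds shown here alone, an aminophenyl or carboxyphenyl group in place of the hydroxyphenyl could answer that, and its effect remains open.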